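From Dimethylphenyl to Dinitrophenyl on the Shared Core

The source may report more compounds than this note shows. Statements on the series, on what has been measured and on what is new or still open speak of the compounds shown alone.

The three measured compounds were all tested in an ADME assay on L02 cells (Homo sapiens) for antiproliferative activity, read by MTT assay, with a stated time of 48 h; on this read-out lower numbers stand for stronger inhibition and higher numbers for weaker inhibition. Compound 1 `COc1ccccc1-n1nncc1CN1C(=O)C2(C(C#N)=C(N)Oc3c(N)cc4nc5ccccc5nc4c32)c2ccccc21` gives > 50000 nM. Compound 2 `Cc1ccc(-n2nncc2CN2C(=O)C3(C(C#N)=C(N)Oc4c(N)cc5nc6ccccc6nc5c43)c3ccccc32)cc1C` gives > 50000 nM. Compound 3 `Cc1ccc(C)c(-n2nncc2CN2C(=O)C3(C(C#N)=C(N)Oc4c(N)cc5nc6ccccc6nc5c43)c3ccccc32)c1` gives > 50000 nM.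

Each of these values is a limit of this assay, not a number: this assay did not reach a half-maximal inhibitory concentration for any of the three, so compound 3 stands at the same limit as its two neighbours, (the limit of > 50000 nM in this assay, at which 3 of the 3 values shown sit). For the measured compounds named here, because of this, the steps between them cannot be read: a step that the two limits leave unreadable from compound 1 to compound 2, a step that the two limits leave unreadable from compound 1 to compound 3 and a step that the two limits leave unreadable from compound 2 to compound 3 are all of unknown size, and say only that exchanging the group on the aromatic nitrogen did not bring any compound below the limit.

Compound 4 `N#CC1=C(N)Oc2c(N)cc3nc4ccccc4nc3c2C12C(=O)N(Cc1cnnn1-c1ccc([N+](=O)[O-])cc1[N+](=O)[O-])c1ccccc12` differs from compound 3 in one place: 2,4-dinitrophenyl in place of 2,5-dimethylphenyl on an aromatic nitrogen. The three unreadable steps bear on this change in kind, since all three exchange the group on the same aromatic nitrogen, but none gives a size. No readable step is therefore expected in this assay, and compound 4 is expected most likely to sit at the limit again, the estimated step being a step that the limit leaves unreadable from compound 3 to compound 4. Compound 4 is estimated at 60000 nM, within a range from 20000 nM to 200000 nM.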

Compound 4, half-maximal inhibitory concentration: 22800 nM
Compound 4: middle estimate off by 2.6-fold (0.42 log units), on the high side, within the range that was stated.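

On the aromatic nitrogen of the five-membered ring, the group can change the read-out in this assay, which the earlier compounds could not show, and 2,4-dinitrophenyl gives the first value in the series that is a number and not a limit: the limit of > 50000 nM in this assay, at which 3 of the 4 values shown sit.

The change from each earlier group gives an at least 2.1-fold lower number from compound 3 to compound 4 (0.34 log units; beyond the scatter), an at least 2.1-fold lower number from compound 2 to compound 4 (0.34 log units; beyond the scatter) and an at least 2.1-fold lower number from compound 1 to compound 4 (0.34 log units; beyond the scatter), so all three comparisons now point the same way, and each gives only the smallest size the step can have, with the true size left open by the limit on the other side. The 2,4-dinitrophenyl group carries hydrogen-bond acceptors where 2,5-dimethylphenyl carries none, but this single change does not tell which feature of the group accounts for the lower number.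

As far as these compounds go, a phenyl ring with a single nitro group remains open, so it cannot be said whether both nitro groups are needed. Also open, from the compounds shown here alone, is what an amine or a carboxylic acid on this ring would give in this assay.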